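Exchanging the Propanoyl Ester for an Amino Acid Ester

The source may report more compounds than this note shows. Statements on the series, on what has been measured and on what is new or still open speak of the compounds shown alone.

Compound 1 `CCOC(=O)C1=C(S[C@@H]2CN[C@H](C(=O)Nc3cccc(C(=O)OCC)c3)C2)[C@H](C)[C@@H]2[C@@H]([C@@H](C)OC(=O)CC)C(=O)N12`: 940 ng.h/mL
Compound 2 `C[C@@H](O)[C@H]1C(=O)N2C3=C(S[C@@H]4CN[C@@H](C4)C(=O)Nc4cccc(c4)C(=O)OCCCOC3=O)[C@H](C)[C@H]12`: "not determined" (no result reported)

Two compounds have been taken into an ADME assay on the whole organism (plasma, strain Beagle) for pharmacokinetics, with Canis familiaris (Canis lupus familiaris) as the target, read by LC-MS, with a stated time of 8 h, at a dose of 10 mg/kg by the intraduodenal route; a lower number here means less compound in the circulation, a higher number more compound in the circulation at the dose given. Among the measured compounds shown here, compound 1 gives 940 ng.h/mL in this assay, and that is the only number reported; for compound 2 the entry in this assay reads "not determined" (no result reported), so there is no second value to set against it. For the measured compounds named here, compound 1 therefore stands alone as the point of reference, and no step between measured compounds can be given.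

Compound 3 `CCOC(=O)C1=C(S[C@@H]2CN[C@H](C(=O)Nc3cccc(C(=O)OCC)c3)C2)[C@H](C)[C@@H]2[C@@H]([C@@H](C)OC(=O)[C@@H](N)C(C)C)C(=O)N12` is the next compound for this assay. It differs from compound 1 in one place: 1-amino-2-methylpropyl in place of ethyl on a carbonyl carbon. The rest of the shared core of compound 1 is kept unchanged.

Going by the values given here, with no measured step of this kind available, the expectation rests on compound 1 alone. The step of a 1.4-fold higher number from compound 1 to compound 3 (0.14 log units; within the scatter) is expected to be modest and upward, of a size that may not clearly exceed the usual scatter of repeated measurements. Compound 3 is accordingly expected to give about 1300 ng.h/mL in this assay, with a range from 450 ng.h/mL to 3800 ng.h/mL.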

Compound 3, area under the concentration-time curve: 631 ng.h/mL
Estimate against measurement, compound 3: 2.1-fold (0.31 log units) above, within the range that was stated.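

In this assay the exchange of ethyl for 1-amino-2-methylpropyl on a carbonyl carbon gives a 1.5-fold lower number from compound 1 to compound 3 (0.17 log units; within the scatter), so the two compounds cannot be told apart on this read-out. Among the compounds shown here, this is the first step that can be read at this position, and it shows that the propanoyl ester can give way to an ester carrying a branched chain with an amine, the new group also bringing a defined stereocentre, without a difference that stands clear of the scatter. The compounds shown offer no measurement that bears on what lies behind this result.

As far as these compounds go, whether aminomethyl, a longer chain ending in an amine, or a carboxylic acid in place of 1-amino-2-methylpropyl on this carbonyl carbon would give a step beyond the scatter remains open, as does the outcome with the opposite configuration at the new stereocentre. A single step on the core of compound 1 also cannot say whether the same exchange would give a similar result on any other core.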